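The source may hold more compounds than are shown below. What is called first, only, known or untested is meant among the compounds shown, and "the series" means these compounds.

Measured compounds:
Compound 1 `O=C(Nc1cccc(-n2cc(-c3ccncc3)c(-c3ccc(Cl)c(O)c3)n2)c1)Nc1cccc(C(F)(F)F)c1`: > 32500 nM
Compound 2 `COc1cc(-c2nn(-c3cccc(NC(=O)Nc4ccc(Cl)c(Cl)c4)c3)cc2-c2ccncc2)ccc1Cl`: > 50000 nM

In a functional assay on ACHN cells (Homo sapiens) for inhibition, read by sulforhodamine B assay, with a stated time of 48 h (a lower number here means a stronger inhibitor of growth, a higher number a weaker inhibitor of growth), compound 1 gives only a limit, > 32500 nM. In this assay compound 2 likewise gives only a limit, > 50000 nM. Compound 2 thus stands at the limit (the limit of > 50000 nM in this assay, at which 1 of the 2 values shown sits), and neither measured compound yields a number. Compound 3 `O=C(Nc1cccc(-n2cc(-c3ccncc3)c(-c3ccc(Cl)c(O)c3)n2)c1)Nc1ccc(Cl)c(Cl)c1` differs from compound 2 in one place: hydrogen in place of methyl on an oxygen on an aromatic ring. Among the measured compounds shown here, no measured pair shows this change, so its size in this assay cannot be read from the data; with both measured values sitting at limits and no growth inhibition seen in either, the step is expected to be none beyond the scatter. Compound 3 is therefore expected to give about 50000 nM, with a range from 20000 nM to 120000 nM, and most likely to be reported once more as a limit. The expected step is a number no higher from compound 2 to compound 3 (the limit leaves the size open).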

Compound 3, concentration for total growth inhibition: > 32500 nM
Compound 3: only a limit was reported; the forecaster's own chance of this, stated with the estimate: 80%; the middle value lies beyond the limit too.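

In this assay compound 3 gives only a limit, > 32500 nM. Compound 1 and compound 2 also give only limits, so neither step to compound 3 can be read. The compounds shown leave open at what concentration, if any, each reaches total growth inhibition.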